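Dimethylamino chain to methoxy chain: working notes

A few compounds are considered here, and "the series" means these few. Any claim that something is new, unique, unknown or untested is made for them only; others in the source may bear on it.

- compound 1 `COC(=O)c1c(NCCN(C)C)n(-c2ccccc2)c(=S)n(-c2ccccc2)c1=O`: 3.32 nM
- compound 2 `CCOC(=O)c1c(NCCCN(C)C)n(-c2ccccc2)c(=S)n(-c2ccccc2)c1=O`: 3.89 nM

In a functional assay on cells (Neutrophil, Homo sapiens) for inhibition, read by transwell migration (on this read-out lower numbers stand for stronger inhibition and higher numbers for weaker inhibition), compound 2 gives 3.89 nM and compound 1 gives 3.32 nM, so the two stand within the scatter of each other.

Compound 3 `CCOC(=O)c1c(NCCOC)n(-c2ccccc2)c(=S)n(-c2ccccc2)c1=O` has not been measured. It differs from compound 2 by methoxy in place of (dimethylamino)methyl on a saturated chain carbon, two bonds along the chain from a nitrogen on an aromatic ring, that is, methoxy in place of (dimethylamino)methyl on a saturated chain carbon. Both measured compounds carry a dimethylamino group on the chain, so the data lack any measured chain without one. The basis is thin, and the range is kept wide. A moderate move toward weaker inhibition is expected, beyond the scatter, and the expected size is a 2.3-fold higher number from compound 2 to compound 3 (0.36 log units; beyond the scatter). The estimated value for compound 3 is 9 nM, with an expected range of 2.5 nM to 35 nM.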

Compound 3, half-maximal inhibitory concentration: 1.36 nM
The estimate for compound 3 lay 6.6-fold (0.82 log units) above the measured number; the whole stated range lies above it.
By their numbers in this assay, from the lowest: compound 3; then compounds 1 and 2 (each within the scatter of the next).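

In this assay, methoxy in place of (dimethylamino)methyl on a saturated chain carbon, two bonds along the chain from a nitrogen on an aromatic ring, gives a 2.9-fold lower number from compound 2 to compound 3 (0.46 log units; beyond the scatter). Within the data shown here, compound 3 is the first compound here whose chain carries no dimethylamino group, and its stronger inhibition shows that this group is not required for activity at this level. Nothing available accounts for the step.

The (3-(dimethylamino)propyl)amino to (2-methoxyethyl)amino change alters both the chain and its end group, so the compounds shown do not separate the contribution of each. From the compounds shown here alone, it also remains open how a 3-methoxypropyl chain, a terminal hydroxyl group or a morpholine at the same place would read out.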